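Changing the Group on the Sulfonamide Nitrogen of Compound 2

This account rests on a few compounds, and the source may have more. Where it says the series, first, only, none or still open, it means among the compounds named here.

Within the data shown here, compound 2 `CN1CCC(NS(=O)(=O)c2ccccc2Nc2cc(-c3ccc4ccn(C)c4c3)c3nccnc3c2)C1` holds the lower of the two numbers measured so far. In an assay for inhibition of 6-phosphofructo-2-kinase/fructose-2,6-bisphosphatase 3 (Homo sapiens), read by ADP-Glo, with a stated time of 2 h (on this read-out higher numbers stand for weaker inhibition and lower numbers for stronger inhibition), compound 2 gives 33 nM, and compound 1 `CNS(=O)(=O)c1ccccc1Nc1cc(-c2ccc3ccn(C)c3c2)c2nccnc2c1` gives 104 nM. Among the measured compounds shown here, the single measured step, a 3.2-fold lower number from compound 1 to compound 2 (0.50 log units; beyond the scatter), shows that putting 1-methylpyrrolidin-3-yl in place of methyl on the sulfonamide nitrogen lowered the number beyond the scatter.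

Compound 3 `Cn1cc(CNS(=O)(=O)c2ccccc2Nc2cc(-c3ccc4ccn(C)c4c3)c3nccnc3c2)cn1` differs from compound 2 in one place: (1-methyl-1H-pyrazol-4-yl)methyl in place of 1-methylpyrrolidin-3-yl on a sulfonamide nitrogen. For the measured compounds named here, only the step from compound 1 to compound 2 bears on this change, and it compares methyl with 1-methylpyrrolidin-3-yl, not with the entering (1-methyl-1H-pyrazol-4-yl)methyl. Nothing measured tells how the entering group compares with the leaving one, so the expectation rests on the two values in hand and is uncertain.

The estimated step is a 1.7-fold higher number from compound 2 to compound 3 (0.22 log units; within the scatter), a modest move toward a higher number, placing compound 3 between the values of compound 1 and compound 2. The estimate for compound 3 in this assay is 55 nM, expected to fall between 20 nM and 160 nM.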

Compound 3, half-maximal inhibitory concentration: 38 nM
Compound 3: middle estimate off by 1.4-fold (0.16 log units), on the high side; low and high end bracket the measured number.
By their numbers in this assay, from the lowest: compounds 2 and 3 (each within the scatter of the next); then compound 1.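

Exchanging 1-methylpyrrolidin-3-yl for (1-methyl-1H-pyrazol-4-yl)methyl on the sulfonamide nitrogen gives a 1.2-fold higher number from compound 2 to compound 3 (0.06 log units; within the scatter), so in this assay this position does not distinguish the non-aromatic ring of compound 2 from the aromatic ring of compound 3. The pyrazole-bearing group also stands apart from methyl, with a 2.7-fold lower number from compound 1 to compound 3 (0.44 log units; beyond the scatter), which shows that the lower number is no longer tied to the 1-methylpyrrolidin-3-yl group alone: both ring-bearing groups shown, in compound 2 and compound 3, lie beyond the scatter of the methyl group in compound 1, and no compound shown goes against this. No measurement is available that explains why these two different groups give numbers within the scatter of each other.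

Compound 2 and compound 3 differ in both the ring and the saturated chain carbon that links it, so these compounds cannot separate the contribution of each. From the compounds shown here alone, it also remains open how a plain benzyl group, an open-chain amine such as 2-(dimethylamino)ethyl, or a carboxylic acid on a longer chain would compare at this sulfonamide nitrogen.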